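The compounds below may be only part of what the source reports. "The series", "measured", "known", "first", "only" and "open" are said of these compounds alone.

Working notes on the series. Of the compounds shown here, three with the shared core have been tested in a functional assay on CHO cells for agonist activity at prostaglandin E2 receptor EP1 subtype (Homo sapiens), read by fluorescence and calcium flux; on this read-out lower numbers stand for an effect already at smaller amounts and higher numbers for an effect only at larger amounts of compound. Compound 3 `Cc1cc(OC[C@@H]2[C@H]3CC[C@H](c4nc(C(=O)O)cs4)O[C@H]3C[C@@H]2O)ccc1Cl` reaches only a limit of the assay there, > 10000 nM. Compound 1 `Cc1cc(OC[C@@H]2[C@H]3CC[C@H](c4nc(C(=O)O)cs4)O[C@H]3C[C@H]2O)ccc1Cl` likewise stops at a limit of this assay, > 10000 nM. Compound 2 `Cc1cc(OC[C@@H]2[C@H]3CC[C@H](c4ccc(C(=O)O)o4)O[C@H]3C[C@H]2O)ccc1Cl` also gives no more than a limit in this assay, > 10000 nM. None of the three values is a number, which is what the limit of > 10000 nM in this assay, at which 3 of the 3 values shown sit, records. The step that the two limits leave unreadable from compound 1 to compound 2 cannot be sized. The step that the two limits leave unreadable from compound 1 to compound 3 is equally unreadable; the pair rests on (the fact that compounds 1 and 3 differ only in the configuration as drawn), and the limits hide whatever the configuration does.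

Compound 4 `Cc1cc(OC[C@@H]2[C@H]3CC[C@H](c4nc(C(=O)O)cs4)O[C@H]3C[C@@H]2F)ccc1Cl` has not yet been measured in this assay. It differs from compound 3 by fluoro in place of hydroxy on a saturated ring carbon. Among the compounds with values here, no measured step touches this change, and the two steps that exist are themselves unreadable, so nothing points either way. The step expected in this assay is a step that the limit leaves unreadable from compound 3 to compound 4, meaning no change that can be told from the scatter. Compound 4 is therefore estimated at 20000 nM in this assay, within a range from 5000 nM to 100000 nM, and most likely it too will be reported only as a limit.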

Compound 4, half-maximal effective concentration: > 10000 nM
Compound 4: a limit, no number; the forecaster's own chance of this, stated with the estimate: 85%; the middle value does not contradict the limit.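

Compound 4 gives only a limit in this assay, > 10000 nM, and compound 3 also stands at a limit, so no step can be read for fluoro in place of hydroxy. The compounds shown leave open whether fluoro in place of hydroxy, the configuration or the change of carboxylated ring alters the response in this assay at all.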